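Swapping Methylsulfanyl for an Arylamine on a Fused Core

The compounds below may be only part of what the source reports. "The series", "measured", "known", "first", "only" and "open" are said of these compounds alone.

The shared core carries a 4-sulfamoylphenyl group in compound 2 `CSc1nn(-c2ccc(S(N)(=O)=O)cc2)c2nc(Nc3ccccc3)n(-c3ccccc3)c(=O)c12` and a plain phenyl in compound 1 `CSc1nn(-c2ccccc2)c2nc(Nc3ccccc3)n(-c3ccccc3)c(=O)c12`. In a functional assay on the whole organism (strain Wistar albino) for inhibition, with Rattus norvegicus as the target, read by paw edema, with a stated time of 1 h, at a dose of 25 mg/kg by the oral route (on this read-out higher numbers stand for more inhibition at the one dose given (going by the name of the read-out) and lower numbers for less inhibition), compound 1 gives 46.1%, and compound 2 gives 68.9%. Among the measured compounds shown here, the one comparison available, a number 22.8 percentage points higher from compound 1 to compound 2 (beyond the scatter), is the only measured step, and it places compound 2 highest of the two numbers, with compound 1 as its only neighbour, beyond the scatter.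

Compound 3 `NS(=O)(=O)c1ccc(-n2nc(Nc3ccc(Cl)cc3)c3c(=O)n(-c4ccccc4)c(Nc4ccccc4)nc32)cc1` keeps the 4-sulfamoylphenyl group but changes a different part of the core: (4-chlorophenyl)amino in place of methylsulfanyl on an aromatic carbon. For the measured compounds named here, no measured step bears on this exchange, since the step from compound 1 to compound 2 concerns the sulfamoyl group and leaves the methylsulfanyl group untouched. With nothing to point in either direction, the expected change in this assay is none beyond the scatter, and the step expected for compound 3 is a number 1.1 percentage points higher from compound 2 to compound 3 (within the scatter). On that basis compound 3 is estimated to give about 70%, with a likely range from 55% to 85%.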

Compound 3, a percentage reported as inhibition, in the whole organism at one dose (the size of the read-out at that dose, not a potency): 69.8%
For compound 3 the middle estimate is 0.2 percentage points above the measured one; measured number inside the range.
By their numbers in this assay, from the lowest: compound 1; then compounds 2 and 3 (each within the scatter of the next).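

In this assay, (4-chlorophenyl)amino in place of methylsulfanyl gives a number 0.9 percentage points higher from compound 2 to compound 3 (within the scatter), so this position on the five-membered ring accepts a group of 8 heavy atoms instead of 2, with an added six-membered aromatic ring and 1 hydrogen-bond donor, without the read-out moving beyond the scatter. Among the compounds shown here, the earlier compounds could not show this, as their only step, a number 22.8 percentage points higher from compound 1 to compound 2 (beyond the scatter), concerns the sulfamoyl group at another place and leaves methylsulfanyl untouched; of the two exchanges, only that one gives a step beyond the scatter. No measurement offered here explains why the read-out stays within the scatter across so large a change in the group.

As far as these compounds go, whether a free amine, a methoxy group or a carboxylic acid at this position would also stay within the scatter remains open, as does the part played by the chlorine on the incoming ring. From the compounds shown here alone, it is also open whether the same exchange would give a similar result on the core of compound 1, which carries a plain phenyl where compound 2 carries its 4-sulfamoylphenyl group.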